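Methylation of the Ring Nitrogen in Compound 3

This account rests on a few compounds, and the source may have more. Where it says the series, first, only, none or still open, it means among the compounds named here.

Measured compounds:
compound 1 `O=C(Nc1ccc(Oc2ccnc3[nH]ccc23)cc1)c1nn(-c2ccc(Cl)c(C(F)(F)F)c2)ccc1=O` 1320 nM
compound 2 `O=C(Nc1ccc(Oc2ccnc3[nH]ccc23)c(F)c1)c1nn(-c2ccc(Cl)c(F)c2)ccc1=O` 9610 nM
compound 3 `O=C(Nc1ccc(Oc2ccnc3[nH]ccc23)c(F)c1)c1nn(-c2ccc(Cl)c(C(F)(F)F)c2)ccc1=O` 11900 nM

In a functional assay on HepG2 cells (Homo sapiens) for cytotoxicity, read by MTT assay, with a stated time of 72 h (on this read-out lower numbers stand for stronger inhibition and higher numbers for weaker inhibition), compound 3 gives the highest of the three numbers. Its nearest neighbour is compound 2, separated by a 1.2-fold higher number from compound 2 to compound 3 (0.09 log units; within the scatter), a step within the scatter. Compound 1 lies furthest away, separated by a 9.0-fold higher number from compound 1 to compound 3 (0.95 log units; beyond the scatter), a step beyond the scatter.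

Compound 4 `Cn1ccc2c(Oc3ccc(NC(=O)c4nn(-c5ccc(Cl)c(C(F)(F)F)c5)ccc4=O)cc3F)ccnc21` has not yet been measured. It differs from compound 3 by methyl in place of hydrogen on an aromatic nitrogen: a hydrogen atom leaves and a methyl group with one carbon enters, on an aromatic nitrogen of a five-membered aromatic ring with one nitrogen, part of a fused system of two rings.

Neither measured step bears on this change. Among the measured compounds shown here, the step from compound 1 to compound 3 concerns a fluoro on an aromatic carbon, and the step from compound 2 to compound 3 exchanges trifluoromethyl for fluoro on an aromatic carbon; no measured pair touches the aromatic nitrogen. There is therefore no measured basis for expecting a step beyond the scatter in this assay. Compound 4 is estimated at 15000 nM, with a range from 5000 nM to 45000 nM, which means an expected step of a 1.3-fold higher number from compound 3 to compound 4 (0.10 log units; within the scatter).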

Compound 4, half-maximal inhibitory concentration: 13500 nM
Estimate against measurement, compound 4: 1.1-fold (0.05 log units) above; measured number inside the range.
By their numbers in this assay, from the lowest: compound 1; then compounds 2, 3 and 4 (each within the scatter of the next).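

In this assay, among the compounds shown here, the step at the aromatic nitrogen of the five-membered aromatic ring is a 1.1-fold higher number from compound 3 to compound 4 (0.05 log units; within the scatter), which gives the first measured reading of any change at this position. The hydrogen on that nitrogen can therefore be exchanged for methyl in compound 3 with the two numbers remaining within the scatter of each other, so this single change has no measurable effect on the read-out here, unlike the fluoro step a 9.0-fold higher number from compound 1 to compound 3 (0.95 log units; beyond the scatter), which lies beyond the scatter. No measurement shown here explains why the methyl group leaves the read-out within the scatter, and the result does not separate a lack of any influence from influences that happen to cancel.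

From the compounds shown here alone, the methyl step has been read only in compound 3, which carries the fluoro, so it remains open whether the same exchange would stay within the scatter in compound 1, whose number is the lowest of the set. Also open, going by these compounds, is whether a group larger than methyl on this nitrogen, such as an ethyl group, a longer chain or a chain ending in an amine or a carboxylic acid, would stay as close to compound 3.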